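The compounds below may be only part of what the source reports. "The series", "measured", "known", "first", "only" and "open" are said of these compounds alone.

Working notes on the series. The shared core is carried by compound 1 `CCCCCC(=O)Nc1cc2nc(C3CCCCC3)[nH]c2cc1N1CCCC1`, compound 2 `CCN(CC)c1cc2[nH]c(C3CCCCC3)nc2cc1NC(=O)c1ccc(N(C)C)cc1` and compound 3 `CCCCCC(=O)Nc1cc2nc(C3CCCCC3)[nH]c2cc1N(CC)CC`; compound 4 `Cc1ccc(C(=O)Nc2cc3nc(C4CCCCC4)[nH]c3cc2N2CCCC2)cc1` has not yet been tested. The read-out throughout is an ADME assay on Vero cells (Chlorocebus sabaeus) for cytotoxicity, read by resazurin assay, with a stated time of 3 days; a lower number here means a stronger inhibitor, a higher number a weaker inhibitor. In this assay compound 1 gives > 100 ug/mL, which is a limit of the assay and not a number. In this assay compound 2 gives "not determined" (no result reported). In this assay compound 3 gives "not determined" (no result reported). Compound 1 therefore stands alone on the numbers shown, with only the limit of > 100 ug/mL in this assay, at which 1 of the 3 values shown sits, as a fixed point, and no step between measured compounds can be drawn from these three entries.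

The change from compound 1 to compound 4 is 4-methylphenyl in place of pentyl on a carbonyl carbon, so that pentylcarbonyl becomes (4-methylphenyl)carbonyl and the (pentylcarbonyl)amino group becomes ((4-methylphenyl)carbonyl)amino. With compound 1 sitting at the limit, no step beyond the scatter is anticipated in either direction, and the expected step from compound 1 to compound 4 in this assay is a number no higher from compound 1 to compound 4 (the limit leaves the size open). Compound 4 is accordingly estimated to give about 100 ug/mL in this assay, within a range from 40 ug/mL to 250 ug/mL, most probably reported once more only as a limit.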

Compound 4, half-maximal inhibitory concentration: > 100 ug/mL
Compound 4: no number, only a limit; the forecaster's own chance of this, stated with the estimate: 70%; the middle value sits exactly at the limit.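

Compound 1 and compound 4 both stop at a limit of the assay and not at a number, so no step can be read between them for 4-methylphenyl in place of pentyl on a carbonyl carbon. The compounds shown leave open whether this change shifts the cytotoxicity read-out at all, and where either compound would fall beyond that limit.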